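The source may report more compounds than this note shows. Statements on the series, on what has been measured and on what is new or still open speak of the compounds shown alone.

Measured so far in an assay on isolated protein for inhibition of RAC-alpha serine/threonine-protein kinase (Homo sapiens), tested at 30 uM; a lower number here means less inhibition, a higher number more inhibition at the concentration tested (going by the name of the read-out):
compound 1 `Cn1cnc2c(Sc3ccccc3)ncnc21` gives 0%
compound 2 `Cn1cnc2c(Sc3ccc(F)cc3)ncnc21` gives 0%
compound 3 `Cn1cnc2c(SCc3ccccc3)ncnc21` gives 4%

Compound 2 differs from compound 1 by fluoro in place of hydrogen on an aromatic carbon; that change gave no change at the digits printed from compound 1 to compound 2 (within the scatter). The difference between the core of compound 1 and the core of compound 3 is not broken down here. In this assay compound 3 and compound 1 lie within the usual scatter of each other, as do compound 3 and compound 2. Compound 4 `Cn1cnc2c(SCc3ccc(F)cc3)ncnc21` is not yet measured and differs from compound 3 by fluoro in place of hydrogen on an aromatic carbon, the same change as in the earlier pair, at a place described in the same words. Beside that earlier step the expected step is no change at the digits printed from compound 3 to compound 4 (within the scatter), resting on the earlier fluoro step, no change at the digits printed from compound 1 to compound 2 (within the scatter). For compound 4 the estimate in this assay is 4%, expected to fall between 0% and 12%.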

Compound 4, a percentage reported as inhibition, at one concentration (the size of the read-out at that concentration, not a potency): 11%
Compound 4: middle estimate off by 7 percentage points, on the low side; low and high end bracket the measured number.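

In this assay, fluoro in place of hydrogen on an aromatic carbon gave a number 7 percentage points higher from compound 3 to compound 4 (within the scatter). Set beside the earlier step, the change carries across the two cores with no difference that can be told apart: the same change on two cores in this assay, no change at the digits printed (within the scatter) from compound 1 to compound 2 and a number 7 percentage points higher (within the scatter) from compound 3 to compound 4, 7 percentage points apart, within the scatter of two such steps. This does not show that fluoro raises inhibition on either core, and a read-out at one concentration with values this small cannot show how the change would carry on a core that gives clear inhibition.

The compounds shown carry only hydrogen or fluoro at this place on the ring. On these data alone, whether another group there, such as an amine, a carboxylic acid or a longer chain, would move the read-out beyond the scatter remains open.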